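Aryl amide variation on the pyridine N-oxide piperidine series

The source may report more compounds than this note shows. Statements on the series, on what has been measured and on what is new or still open speak of the compounds shown alone.

Measured so far:
compound 1 `Cc1cc(NC(=O)CN2CCC(c3cccc[n+]3[O-])CC2)ccc1F` — 18 nM
compound 2 `Cc1cc(F)ccc1NC(=O)CN1CCC(c2cccc[n+]2[O-])CC1` — 60 nM

Both compounds share the same core and differ only in the aryl group on the amide-type nitrogen. In a functional assay on HEK293 cells for agonist activity at D(4) dopamine receptor (Homo sapiens), read by FLIPR (on this read-out higher numbers stand for an effect only at larger amounts of compound and lower numbers for an effect already at smaller amounts), compound 1 gives 18 nM, and compound 2 gives 60 nM. For the measured compounds named here, the single measured step, a 3.3-fold higher number from compound 1 to compound 2 (0.52 log units; beyond the scatter), is the only comparison available. Compound 2 therefore stands with the highest of the two numbers, and its nearest neighbour is compound 1 by that same step.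

Compound 3 `Cc1cccc(C)c1NC(=O)CN1CCC(c2cccc[n+]2[O-])CC1` is not yet measured. It carries 2,6-dimethylphenyl in place of 4-fluoro-2-methylphenyl on an amide-type nitrogen. Going by the values given here, no measured step covers a fluorine-to-methyl exchange or a second methyl on this aryl group, so the one step from compound 1 to compound 2 bears on it only loosely: it shows that moving a methyl on this aryl group changes the number by a modest amount. On that basis the estimated step is a 2.0-fold higher number from compound 2 to compound 3 (0.30 log units; within the scatter), a modest rise without a clear precedent for direction. Compound 3 is therefore expected to give about 120 nM, with a range from 35 nM to 500 nM.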

Compound 3, half-maximal effective concentration: 346 nM
The estimate for compound 3 lay 2.9-fold (0.46 log units) below the measured number, and the stated range covers the measured number.
By their numbers in this assay, from the lowest: compound 1; then compound 2; then compound 3.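

Working notes on the aryl group on the amide-type nitrogen: in this assay, 2,6-dimethylphenyl in place of 4-fluoro-2-methylphenyl gives a 5.8-fold higher number from compound 2 to compound 3 (0.76 log units; beyond the scatter), even though the computed counts of heavy atoms, donors and acceptors are the same for both groups. Set against the 4-fluoro-3-methylphenyl group, the same 2,6-dimethylphenyl group gives a 19-fold higher number from compound 1 to compound 3 (1.28 log units; beyond the scatter), a large step that shows this position can move the number well beyond the modest change seen among the fluorinated groups, with the shared core held constant. No measurement at hand explains this rise.

The step to compound 3 removes the fluorine and changes the methyl pattern in one exchange, so the compounds shown do not separate the contribution of either change, and 2-methylphenyl or plain phenyl on the same nitrogen would bear directly on that. Also open, going by these compounds, is whether the high number belongs to the 2,6-dimethylphenyl group specifically or extends to other groups carrying two substituents in the same places, such as 2,6-dichlorophenyl.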